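Adding a methyl to the 1-hydroxyethyl group

The compounds below may be only part of what the source reports. "The series", "measured", "known", "first", "only" and "open" are said of these compounds alone.

Values in a functional assay on A2780 cells (Homo sapiens) for inhibition, read by sulforhodamine B assay, with a stated time of 96 h (on this read-out higher numbers stand for weaker inhibition of growth and lower numbers for stronger inhibition of growth), for the measured compounds:
Compound 1 `CCC(O)[C@@H](CC)Nc1nc(NCc2ccccn2)c2ncn(C(C)C)c2n1` gives 40000 nM
Compound 2 `CC[C@H](Nc1nc(NCc2ccccn2)c2ncn(C(C)C)c2n1)C(C)O` gives 17000 nM

Of these two, compound 2 holds the lower number and so shows the stronger inhibition of growth. Compound 3 `CC[C@H](Nc1nc(NCc2ccccn2)c2ncn(C(C)C)c2n1)C(C)(C)O` is still unmeasured. Its difference from compound 2 is methyl in place of hydrogen on a saturated chain carbon bound to an oxygen on a saturated carbon and two saturated chain carbons and this turns 1-hydroxyethyl to 1-hydroxy-1-methylethyl. Among the compounds with values here, only one measured step bears on this change, and it concerns the same side chain: a 2.4-fold lower number from compound 1 to compound 2 (0.37 log units; beyond the scatter) was modest. A single step gives only a rough guide to size and none to direction for this added methyl. In this assay little change is therefore expected, probably nothing beyond the scatter, and the estimate means only a slight rise in the number (a 1.2-fold higher number from compound 2 to compound 3 (0.07 log units; within the scatter)). For compound 3 the estimate is 20000 nM (expected range from 8000 nM to 50000 nM).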

Compound 3, concentration for 50% growth inhibition: 44000 nM
Beside the measured number, compound 3's estimate is 2.2-fold (0.34 log units) below it; measured number inside the range.
By their numbers in this assay, from the lowest: compound 2; then compounds 1 and 3 (each within the scatter of the next).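

In this assay, within the data shown here, the added methyl gives a direction that the earlier compounds could not, and it is upward: a 2.6-fold higher number from compound 2 to compound 3 (0.41 log units; beyond the scatter) shows that turning 1-hydroxyethyl to 1-hydroxy-1-methylethyl modestly weakens inhibition of growth. This removes the advantage that compound 2 held, and a 1.1-fold higher number from compound 1 to compound 3 (0.04 log units; within the scatter) lies within the scatter, so compound 3 and compound 1 stand level despite their different side chains. Nothing given here explains the effect of the added methyl.

Going by these compounds, it remains open whether an ethyl in place of this methyl would carry the same penalty, or whether an amine in place of the hydroxyl would change the result. The compounds shown also leave open whether this step would hold on a side chain other than 1-(1-hydroxyethyl)propyl.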